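Replacing 1H-benzimidazol-1-yl with pyrimidin-5-yl in an antiproliferative series

The source may hold more compounds than are shown below. What is called first, only, known or untested is meant among the compounds shown, and "the series" means these compounds.

Three compounds with a number or an entry frame this account in a functional assay on PC-3 cells (Homo sapiens) for antiproliferative activity, read by CCK-8 assay, with a stated time of 6 days; on this read-out higher numbers stand for weaker inhibition and lower numbers for stronger inhibition. For compound 1 `N#Cc1ccc(N2CCc3cc(-c4cnc5ccccc5c4)ccc32)cc1C(F)(F)F` the entry reads "not determined" (no result reported), so it offers no number for comparison. Compound 2 `CCN(c1ccc(C#N)c(Cl)c1)c1cc(-c2cnc3ccccc3c2)ccc1C` gives 3570 nM. Compound 3 `CCN(c1ccc(C#N)c(Cl)c1)c1cc(-n2cnc3ccccc32)ccc1C` gives 8160 nM, the higher of the two numbers, and its gap to compound 2 lies beyond the usual scatter of repeated measurements.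

Compound 4 `CCN(c1ccc(C#N)c(Cl)c1)c1cc(-c2cncnc2)ccc1C` has not yet been measured. It carries pyrimidin-5-yl in place of the 1H-benzimidazol-1-yl of compound 3, on an aromatic carbon, meta to a large group and para to a methyl group: pyrimidin-5-yl in place of 1H-benzimidazol-1-yl on an aromatic carbon. Within the data shown here, no measured pair shows a change of this kind, so the expectation rests on very little. Among the measured compounds shown here, the only close neighbour with a number is compound 2, which has another group at this same place and gives 3570 nM. A modest move towards a lower number is therefore expected, with no step beyond the scatter. The expected step is a 1.5-fold lower number from compound 3 to compound 4 (0.17 log units; within the scatter). In this assay compound 4 is estimated at 5500 nM, with an expected range from 2000 nM to 15000 nM.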

Compound 4, half-maximal inhibitory concentration: > 30000 nM
Compound 4: no number, only a limit (the forecaster's own chance of this, stated with the estimate: 10%); at least 5.4-fold (0.73 log units) between middle value and limit.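

In this assay, among these compounds, putting pyrimidin-5-yl in place of 1H-benzimidazol-1-yl on this aromatic carbon gives an at least 3.6-fold higher number from compound 3 to compound 4 (0.56 log units; beyond the scatter), the first single change at this place for which a step can be read. The entry for compound 4 is a limit and not a number, so the step has a lower bound but no known size: the limit of > 30000 nM in this assay, at which 1 of the 4 values shown sits. The two groups carry the same count of hydrogen-bond acceptors and no net charge, so these counts do not separate them; what the change does alter is the ring set, with one six-membered aromatic ring with 2 hetero atoms replacing a five-membered aromatic ring with 2 hetero atoms and a six-membered aromatic ring of carbon only.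

This single pair cannot show which part of that ring change matters, or how far the number of compound 4 lies beyond its limit. It also leaves open how this place would respond to a phenyl ring, a pyridin-3-yl group or a morpholin-4-yl group on the same aromatic carbon, any of which would test whether the two ring nitrogens of pyrimidin-5-yl or its single ring goes with the loss.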